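From Methoxycarbonyl to Ethoxycarbonyl on a Shared Core

The source may report more compounds than this note shows. Statements on the series, on what has been measured and on what is new or still open speak of the compounds shown alone.

For the measured compounds named here, in a functional assay on A549 cells (Homo sapiens) for antiproliferative activity, read by MTT assay, with a stated time of 48 h (a higher number here means a weaker inhibitor of growth, a lower number a stronger inhibitor of growth), compound 2 `COC(=O)N1N=C(c2cccc(O)c2)CC1c1cc(OC)c(OC)c(OC)c1` gives 3170 nM as one of only two measured numbers. Compound 1 `CCOC(=O)N1N=C(c2cccc(OC)c2)CC1c1cc(OC)c(OC)c(OC)c1` gives 5920 nM in this assay and so lies within the usual scatter of compound 2. Going by the values given here, these two compounds differ in more than one place, so no measured pair isolates a single change.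

Compound 3 `CCOC(=O)N1N=C(c2cccc(O)c2)CC1c1cc(OC)c(OC)c(OC)c1` alters compound 2 in one place: methyl in place of hydrogen on a saturated chain carbon bound to an oxygen next to a carbonyl group with methyl in place of hydrogen on a saturated chain carbon bound to an oxygen next to a carbonyl group, so methoxycarbonyl becomes ethoxycarbonyl. Compound 1 also carries ethoxycarbonyl, and its 5920 nM stays within the scatter of compound 2, so no shift beyond the scatter is expected in this assay here. The expected step is a 1.1-fold higher number from compound 2 to compound 3 (0.06 log units; within the scatter) and would remain within that scatter. The estimated value for compound 3 is 3600 nM with an expected range from 1500 nM to 8000 nM for this compound.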

Compound 3, concentration for 50% growth inhibition: 5120 nM
Compound 3: middle estimate off by 1.4-fold (0.15 log units), on the low side, within the range that was stated.
By their numbers in this assay, from the lowest: compounds 2, 3 and 1 (each within the scatter of the next).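

For the compounds shown here, compound 3 supplies the first measured pairs that differ in only one place. In this assay the change from methoxycarbonyl to ethoxycarbonyl is a 1.6-fold higher number from compound 2 to compound 3 (0.21 log units; within the scatter) and so does not separate the two compounds, while hydrogen in place of methyl on an oxygen on an aromatic ring is a 1.2-fold lower number from compound 1 to compound 3 (0.06 log units; within the scatter) and does not separate those two either. Nothing available here bears on the reason for these two results.

Both changes are single, one-carbon edits, so the compounds shown say nothing about larger groups in these places. From the compounds shown here alone, whether a longer chain such as butoxycarbonyl, or an amine attached to the carbonyl in place of the ethoxy group, would move the number beyond the scatter remains open.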